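The compounds below may be only part of what the source reports. "The series", "measured", "known", "first", "only" and "open" are said of these compounds alone.

Measured compounds in a functional assay on A2780 cells (Homo sapiens) for antiproliferative activity, read by fluorescence, with a stated time of 72 h; a lower number here means a stronger inhibitor, a higher number a weaker inhibitor:
- compound 1 `CC(C)(C)C(=O)N1Cc2c(NC(=O)C3CCNCC3)n[nH]c2C1(C)C`: 650 nM
- compound 2 `CN1CCC(C(=O)N2Cc3c(NC(=O)C4CCC4)n[nH]c3C2(C)C)CC1`: 140 nM

Compound 2 holds the lower of the two numbers in this assay, and its gap to compound 1 lies beyond the scatter. Among the compounds with values here, the two differ in more than one place, so no single-change step is available as a guide. Compound 3 `CN1CCC(C(=O)N2Cc3c(NC(=O)c4cc(F)cc(F)c4)n[nH]c3C2(C)C)CC1` has 3,5-difluorophenyl in place of cyclobutyl on a carbonyl carbon. The expected change is a 1.8-fold lower number from compound 2 to compound 3 (0.24 log units; within the scatter), a modest move towards a lower number that may not exceed the scatter. In this assay the estimated value for compound 3 is 80 nM, with an expected range from 15 nM to 400 nM.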

Compound 3, half-maximal inhibitory concentration: 130 nM
Compound 3: the middle estimate sits 1.6-fold (0.21 log units) below what was measured; measured number inside the range.
By their numbers in this assay, from the lowest: compounds 3 and 2 (each within the scatter of the next); then compound 1.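

In this assay, within the data shown here, the first single-change step at this carbonyl carbon reads a 1.1-fold lower number from compound 2 to compound 3 (0.03 log units; within the scatter) and so separates the two compounds by no more than the usual scatter. At this position, the assay therefore does not tell 3,5-difluorophenyl from cyclobutyl, although the incoming ring is aromatic and has more heavy atoms. Nothing available accounts for this result.

As far as these compounds go, whether an unsubstituted phenyl or a cyclohexyl group on this carbonyl would give a similar number remains open. So does the separate contribution of the two fluorine atoms.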